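Nitro in place of iodo: working notes on the series

A few compounds are considered here, and "the series" means these few. Any claim that something is new, unique, unknown or untested is made for them only; others in the source may bear on it.

- Compound 1 `Fc1ccccc1C1=NC(c2ccccc2)CO1` gives 3.51
- Compound 2 `Ic1ccccc1C1=NC(c2ccccc2)CO1` gives 3.86
- Compound 3 `O=[N+]([O-])c1ccccc1C1=NC(c2ccccc2)CO1` is not yet measured

Among the measured compounds shown here, in a physicochemical assay for lipophilicity (a higher number here means a more lipophilic compound, a lower number a more polar compound), compound 2 stands at 3.86 as the higher of the two measured compounds, and compound 1 at 3.51 is its only neighbour. The next change leads to compound 3, with nitro in place of iodo on an aromatic carbon (this is the whole difference between the two structures).

For the measured compounds named here, only one measured step bears on this change, iodo in place of fluoro on an aromatic carbon: a number 0.35 log units higher from compound 1 to compound 2 (beyond the scatter) (the sole guide to size). Going by the values given here, no measured compound carries nitro, so the guidance is indirect and the range must stay wide. With iodo leaving the higher compound of the pair, a fall in this assay is expected, somewhat larger than the measured step and beyond the scatter. The estimated change is a number 0.56 log units lower from compound 2 to compound 3 (beyond the scatter) (an expectation, not a measurement). For compound 3 the expected value is 3.3 with an estimated range from 2.9 to 3.6 (still to be tested).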

Compound 3, partition coefficient: 2.83
Compound 3: the middle estimate sits 0.47 log units above what was measured; measured number below the stated range.
By their numbers in this assay, from the lowest: compound 3; then compound 1; then compound 2.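

Nitro at this position, on an aromatic carbon ortho to a large group, takes the series outside the span set by the two halogens in this assay: compound 3 is now the lowest of the three, with a number 1.03 log units lower from compound 2 to compound 3 (beyond the scatter) and a number 0.68 log units lower from compound 1 to compound 3 (beyond the scatter) in the two comparisons. The earlier a number 0.35 log units higher from compound 1 to compound 2 (beyond the scatter) showed only a modest spread between fluoro and iodo, whereas the replacement of iodo by nitro gives a large step, so this position can carry a much wider spread in this assay than the halogen pair alone revealed. The swap changes several counted features at once, including heavy atoms, hydrogen-bond acceptors and a double bond outside aromatic rings, and nothing available here gives a measured reason for the size of the fall.

With only three groups at one position, the compounds shown leave open where a methoxy group, an amine or a carboxylic acid at the same place would fall relative to compound 3. They also leave open whether nitro in place of iodo would give a step of similar size at another aromatic carbon or on a different core.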